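Methoxy for Chloro on the Isopropoxyphenyl Ring

The source may report more compounds than this note shows. Statements on the series, on what has been measured and on what is new or still open speak of the compounds shown alone.

For the measured compounds named here, the two compounds measured so far share a core and differ in the group placed on the aromatic ring that carries the isopropoxy group. Compound 1 `CCOc1ccc(-c2nc(-c3ccc(CCC(=O)O)cc3C)no2)cc1C(F)(F)F` carries a trifluoromethyl group there, together with an ethoxy group, and in a functional assay on CHO cells for agonist activity at sphingosine 1-phosphate receptor 5 (Homo sapiens), read by GTPgammaS binding (on this read-out higher numbers stand for an effect only at larger amounts of compound and lower numbers for an effect already at smaller amounts), compound 1 gives 260 nM. Compound 2 `Cc1cc(CCC(=O)O)ccc1-c1noc(-c2ccc(OC(C)C)c(Cl)c2)n1` carries a chloro group and an isopropoxy group, and in this assay compound 2 gives 140 nM. The two values lie within the usual scatter of each other, so neither compound can be set apart from the other on these numbers.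

Compound 3 `COc1cc(-c2nc(-c3ccc(CCC(=O)O)cc3C)no2)ccc1OC(C)C` is the next member: methoxy in place of chloro on an aromatic carbon. Going by the values given here, no measured pair shows this kind of exchange, so the expected step rests on the structural change alone. A modest weakening, or no change beyond the scatter, is expected for a 1.8-fold higher number from compound 2 to compound 3 (0.25 log units; within the scatter). Compound 3 is therefore estimated at 250 nM, with a plausible range from 80 nM to 800 nM.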

Compound 3, half-maximal effective concentration: 270 nM
Compound 3: middle estimate off by 1.1-fold (0.03 log units), on the low side; measured number inside the range.
By their numbers in this assay, from the lowest: compounds 2, 1 and 3 (each within the scatter of the next).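

In this assay, methoxy in place of chloro on an aromatic carbon ortho to an isopropoxy group gives a 1.9-fold higher number from compound 2 to compound 3 (0.29 log units; within the scatter). For the compounds shown here, compounds 1 and 2 differ in more than one place, so this pair is the first to isolate a single exchange at this position, and on these numbers the exchange cannot be told apart from no effect, even though methoxy brings one more heavy atom and a hydrogen-bond acceptor. Nothing available explains this result.

Going by these compounds, whether an amine, a nitrile or a longer alkoxy chain at this position would shift the number beyond the scatter remains open. Also open, on these data alone, is whether the same exchange of chloro for methoxy would give a similar step in a compound carrying ethoxy in place of isopropoxy.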